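Stereocentre inversion in the imidazolylpropyl pyrrolinone series

The compounds below may be only part of what the source reports. "The series", "measured", "known", "first", "only" and "open" are said of these compounds alone.

Two members of the series have numbers in a functional assay on SAOS-2 cells (Homo sapiens) for antiproliferative activity, read by MTT assay, with a stated time of 72 h (a lower number here means a stronger inhibitor, a higher number a weaker inhibitor), so far. Compound 1 `O=C(C1=C(Nc2cccc(Br)c2)C(=O)N(CCCn2ccnc2)C1c1ccc(Br)cc1)c1ccccc1`, drawn without configuration at either stereocentre, gives 9090 nM in this assay. Compound 2 `C[C@@H](NC1=C(C(=O)c2ccccc2)[C@@H](c2ccc(Br)cc2)N(CCCn2ccnc2)C1=O)c1ccccc1`, with both stereocentres defined, gives 27500 nM in this assay, the higher of the two numbers: the gap to compound 1 is beyond the scatter, so compound 2 is the weaker of the two measured compounds.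

Compound 3 `C[C@@H](NC1=C(C(=O)c2ccccc2)[C@H](c2ccc(Br)cc2)N(CCCn2ccnc2)C1=O)c1ccccc1` is the next case. Relative to compound 2 the change is the two compounds have the same atoms and bonds and differ only in configuration as drawn: 1 of 2 stereo elements differ; a stereocentre at a saturated ring carbon is drawn R in compound 2 and S in compound 3; in words, the two compounds have the same atoms and bonds and differ only in configuration as drawn, with the stereocentre at the saturated ring carbon drawn R in compound 2 and S in compound 3.

Among the compounds with values here, no measured pair shows what such an inversion does. With compound 2 sitting at the weak end of the two numbers, a move toward a lower number seems the more likely outcome for compound 3, but a step either way within or somewhat beyond the scatter cannot be excluded. Compound 3 is therefore expected at 15000 nM in this assay, with a range of 5000 nM to 45000 nM, which corresponds to an expected step of a 1.8-fold lower number from compound 2 to compound 3 (0.26 log units; within the scatter).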

Compound 3, half-maximal inhibitory concentration: 13200 nM
Compound 3: middle estimate off by 1.1-fold (0.06 log units), on the high side; the measured number falls inside the stated range.
By their numbers in this assay, from the lowest: compounds 1 and 3 (each within the scatter of the next); then compound 2.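

In this assay, the series now has its first pair that isolates configuration at the saturated ring carbon: going from R to S gives a 2.1-fold lower number from compound 2 to compound 3 (0.32 log units; beyond the scatter), a modest step but one that lies beyond the scatter. This position therefore registers in the read-out even when atoms and bonds stay the same, with the S form as drawn giving the lower number in this one pair, something the first two compounds could not show because they differ in more than one place. The step can be assigned to this single stereocentre, with the second stereocentre drawn the same in both compounds, because nothing else separates the pair: the fact that compounds 2 and 3 differ only in the configuration as drawn

The compounds shown leave open what inversion of the second stereocentre would do, alone or together with the ring carbon, so the full set of configurations remains unresolved. Also open, from the compounds shown here alone, is whether the same direction and size of step would hold with a carboxylic acid or a longer chain in place of the imidazolylpropyl group.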